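This account rests on a few compounds, and the source may have more. Where it says the series, first, only, none or still open, it means among the compounds named here.

Measured compounds:
- compound 1, `COc1cc(N(Cc2nc3ccccc3[nH]2)S(=O)(=O)c2ccccc2)cc(OC)c1OC`, with 12400 nM
- compound 2, `COc1cc(N(Cc2nc3ccccc3[nH]2)S(=O)(=O)c2ccc(Br)cc2)cc(OC)c1OC`, with 2190 nM
- compound 3, `COc1cc(N(Cc2nc3ccccc3[nH]2)C(=O)c2ccccc2)cc(OC)c1OC`, with > 50000 nM

In a functional assay on MGC-803 cells (Homo sapiens) for inhibition, read by MTT assay, with a stated time of 48 h (on this read-out lower numbers stand for stronger inhibition and higher numbers for weaker inhibition), compound 1 gives 12400 nM. Compound 2 gives 2190 nM, and the change a 5.7-fold lower number from compound 1 to compound 2 (0.75 log units; beyond the scatter) is the one clear gain among the three. Going by these compounds, for compound 3 the assay reports only a limit, > 50000 nM, so compound 3 sits at the limit of > 50000 nM in this assay, at which 1 of the 3 values shown sits, and its true number is unknown beyond that. The moves an at least 4.0-fold higher number from compound 1 to compound 3 (0.60 log units; beyond the scatter) and an at least 22-fold higher number from compound 2 to compound 3 (1.35 log units; beyond the scatter) show that swapping the sulfonyl linker for a carbonyl weakened inhibition, at least to the limit of this assay.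

Compound 4, `COc1cc(N(Cc2nc3ccccc3[nH]2)C(=O)c2ccc(F)cc2)cc(OC)c1OC`, is not yet measured. It differs from compound 3 by fluoro in place of hydrogen on an aromatic carbon. On these data alone, the closest measured step is the bromo addition, a 5.7-fold lower number from compound 1 to compound 2 (0.75 log units; beyond the scatter), which helped on the sulfonyl series; whether a fluoro on the benzoyl series behaves the same way is untested, and the start point is only a limit. A modest improvement is the most that these data support, and compound 3 could itself lie far above the limit, so the number for compound 4 is expected to stay high: in this assay compound 4 is estimated at 40000 nM, between 10000 nM and 150000 nM, a step of an at least 1.2-fold lower number from compound 3 to compound 4 (0.09 log units; that floor lies within the scatter) that is expected to remain weak.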

Compound 4, half-maximal inhibitory concentration: 23600 nM
Beside the measured number, compound 4's estimate is 1.7-fold (0.23 log units) above it, within the range that was stated.
By their numbers in this assay, from the lowest: compound 2; then compounds 1 and 4 (each within the scatter of the next). At a limit, above all of these: compound 3.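

Adding one fluoro to the benzoyl group, para to a large group, gives a real gain in this assay (an at least 2.1-fold lower number from compound 3 to compound 4 (0.32 log units; beyond the scatter)), so a halogen on this ring lowers the number on the carbonyl compounds as well as on the sulfonyl pair, where bromo gave a similar benefit (a 5.7-fold lower number from compound 1 to compound 2 (0.75 log units; beyond the scatter)). The carbonyl linker also no longer means a clear loss in every case: compound 4 cannot be told apart from the unsubstituted sulfonyl compound 1 (a 1.9-fold higher number from compound 1 to compound 4 (0.28 log units; within the scatter)), although the bromo sulfonyl compound 2 keeps a wide lead (an 11-fold higher number from compound 2 to compound 4 (1.03 log units; beyond the scatter)). Going by these compounds, compound 3 has only a limit, so the true size of the fluoro gain stays unknown and only its lower bound can be read: the limit of > 50000 nM in this assay, at which 1 of the 4 values shown sits.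

Still open, on these data alone, is how a bromo on the benzoyl group or a fluoro on the phenylsulfonyl group would compare, so the effect of the halogen cannot yet be separated from that of the linker. The compounds shown also leave open how a methoxy group, an amine or a carboxylic acid would behave at this same place on the ring.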